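The source may hold more compounds than are shown below. What is called first, only, known or untested is meant among the compounds shown, and "the series" means these compounds.

Compound 1 `O=C1NC(=O)/C(=C/c2cn(Cc3ccccc3)c3ccccc23)N1`: > 40000 nM
Compound 2 `N#Cc1ccc(Cn2cc(/C=C3\NC(=O)NC3=O)c3ccccc32)cc1`: > 40000 nM
Compound 3 `COC(=O)c1ccc(Cn2cc(/C=C3\NC(=O)NC3=O)c3ccccc32)cc1`: > 40000 nM

Each entry from a functional assay on A549 cells (Homo sapiens) for antiproliferative activity, read by trypan blue exclusion, with a stated time of 24 h (a higher number here means a weaker inhibitor, a lower number a stronger inhibitor), is a limit and not a number, as the limit of > 40000 nM in this assay, at which 3 of the 3 values shown sit, shows. Compound 3 thus has only a limit, > 40000 nM. Compound 4 `O=C1NC(=O)/C(=C/c2cn(Cc3ccc(F)cc3)c3ccccc23)N1` differs from it by fluoro in place of methoxycarbonyl on an aromatic carbon, with fluoro in place of methoxycarbonyl on an aromatic carbon. Within the data shown here, three measured steps bear on this change: a step that the two limits leave unreadable from compound 1 to compound 3, a step that the two limits leave unreadable from compound 2 to compound 3 and a step that the two limits leave unreadable from compound 1 to compound 2. None has a readable size, so they give no direction for this assay. The expectation of no step beyond the scatter rests on compound 1, whose limit is > 40000 nM. The expected step is a step that the limit leaves unreadable from compound 3 to compound 4. Compound 4 is estimated at 45000 nM, with an expected range of 20000 nM to 80000 nM.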

Compound 4, half-maximal inhibitory concentration: 27800 nM
Estimate against measurement, compound 4: 1.6-fold (0.21 log units) above, within the range that was stated.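

In this assay, fluoro on this aromatic carbon is the only group shown here that gives a number rather than a limit of the assay: the limit of > 40000 nM in this assay, at which 3 of the 4 values shown sit.

The change gives an at least 1.4-fold lower number from compound 3 to compound 4 (0.15 log units; that floor lies within the scatter), an at least 1.4-fold lower number from compound 2 to compound 4 (0.15 log units; that floor lies within the scatter) and an at least 1.4-fold lower number from compound 1 to compound 4 (0.15 log units; that floor lies within the scatter). These floors therefore do not separate fluoro from hydrogen, cyano or methoxycarbonyl.

From the compounds shown here alone, how large the true steps are remains open, as the other three compounds carry only limits. Also open, going by these compounds, is whether chloro, methoxy or an amine on this carbon would give a lower number.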